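A second fluoro on the (3-fluorophenyl)sulfonyl group

The compounds below may be only part of what the source reports. "The series", "measured", "known", "first", "only" and "open" are said of these compounds alone.

Compound 2 `O=C(NCc1ccc(CNS(=O)(=O)c2cccc(F)c2)cc1)c1ccc(CNc2ncccn2)cc1` stands highest of the two numbers in an assay on MDA-MB-231 cells for binding affinity to C-X-C chemokine receptor type 4 (Homo sapiens), read by microscopy, with stated times of 10 min and 30 min (on this read-out lower numbers stand for an effect already at smaller amounts and higher numbers for an effect only at larger amounts of compound), where compound 2 gives 1000 nM; its nearest neighbour, compound 1 `Cc1cccc(S(=O)(=O)NCc2ccc(CNC(=O)c3ccc(CNc4ncccn4)cc3)cc2)c1`, gives 100 nM. For the measured compounds named here, the only step measured so far is a 10-fold higher number from compound 1 to compound 2 (1.00 log units; beyond the scatter), an exchange of one group for another rather than an addition. Compound 3 `O=C(NCc1ccc(CNS(=O)(=O)c2ccc(F)c(F)c2)cc1)c1ccc(CNc2ncccn2)cc1` differs from compound 2 by fluoro in place of hydrogen on an aromatic carbon. Going by the values given here, no measured step adds a second fluoro, so nothing bears directly on this change. The expected step is therefore no change at the digits printed from compound 2 to compound 3 (within the scatter), not beyond the scatter. The estimate for compound 3 is 1000 nM, with a range of 400 nM to 2500 nM.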

Compound 3, effective concentration (reported as EC, without a stated level of effect): 100 nM
Beside the measured number, compound 3's estimate is 10-fold (1.00 log units) above it; the whole stated range lies above it.
By their numbers in this assay, from the lowest: compounds 1 and 3 (each within the scatter of the next); then compound 2.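

In this assay, the aromatic carbon ortho to a fluoro group and para to a large group proves responsive to substitution, with fluoro in place of hydrogen giving a 10-fold lower number from compound 2 to compound 3 (1.00 log units; beyond the scatter). Set against the 3-methylphenyl group on the sulfonyl sulfur, the 3,4-difluorophenyl group gives no change at the digits printed from compound 1 to compound 3 (within the scatter), so a fluoro-bearing ring is not tied to the higher number of compound 2. No measured evidence accounts for this step.

On these data alone, whether a chloro, methoxy or amino group on this carbon would behave as fluoro does stays open. Also open, as far as these compounds go, is whether this fluoro would give the same step on the methyl-bearing ring of compound 1.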